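Chloro in Place of Methoxy, Starting From a Limit

The source may report more compounds than this note shows. Statements on the series, on what has been measured and on what is new or still open speak of the compounds shown alone.

Compound 1 `O=C(/C=C\Nc1ccc(F)cc1)c1nc(-c2ccc(C(F)(F)F)cc2)n2ccccc12` sets the shared core of this small set. In a functional assay on BT-474 cells (Homo sapiens) for cytotoxicity, read by MTT assay, with a stated time of 48 h (on this read-out higher numbers stand for weaker inhibition and lower numbers for stronger inhibition), compound 1 gives > 30000 nM, which is a limit of the assay rather than a number. Compound 2 `COc1ccc(N/C=C\C(=O)c2nc(-c3ccc(C(F)(F)F)cc3)n3ccccc23)cc1` carries methoxy in place of fluoro on an aromatic carbon. In this assay compound 2 gives > 30000 nM, again a limit and not a number. The step that the two limits leave unreadable from compound 1 to compound 2 therefore has no readable size, because both of its ends sit at the limit of > 30000 nM in this assay, at which 2 of the 2 values shown sit. Compound 2 thus stands at the limit, with no measured number of its own.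

Compound 3 `O=C(/C=C\Nc1ccc(Cl)cc1)c1nc(-c2ccc(C(F)(F)F)cc2)n2ccccc12` differs from compound 2 in one place: chloro in place of methoxy on an aromatic carbon. Among the compounds with values here, no measured step bears directly on this change, and the only step in the set, methoxy in place of fluoro, is unreadable. There is no basis for expecting a move out of the limit. The step is therefore expected to be a step that the limit leaves unreadable from compound 2 to compound 3, nothing beyond the scatter. Compound 3 is estimated to give 40000 nM, within 15000 nM to 120000 nM, most likely reported again as a limit.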

Compound 3, half-maximal inhibitory concentration: 3820 nM
Compound 3: middle estimate off by 10-fold (1.02 log units), on the high side, and the stated range ends above it.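

In this assay, the aromatic carbon para to a large group turns out to matter: the group placed there can bring a compound off the limit and onto a measured number, something neither earlier compound showed. Chloro in place of methoxy gives an at least 7.8-fold lower number from compound 2 to compound 3 (0.89 log units; beyond the scatter), and chloro in place of fluoro gives an at least 7.8-fold lower number from compound 1 to compound 3 (0.89 log units; beyond the scatter), so two different starting groups lead to the same gain once chloro enters. Both steps give only the smallest possible size rather than a full one, since each starts from a compound without a number of its own: the limit of > 30000 nM in this assay, at which 2 of the 3 values shown sit.

The compounds shown cannot tell whether chloro is unusual at this carbon or simply the first group here to give a number, and bromo, methyl or a nitrile at the same place would help to separate those two readings. Going by these compounds, how far the fluoro and methoxy compounds really lie from the chloro compound also stays open, and so does whether the same swap would matter anywhere else on this ring.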